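This account rests on a few compounds, and the source may have more. Where it says the series, first, only, none or still open, it means among the compounds named here.

Compound 1 `Cc1ccc(Nc2nc(-c3ccncc3)cs2)cc1` carries a methyl on an aromatic carbon of its shared core; in a functional assay on RCC4 cells (Homo sapiens) for inhibition, read by XTT assay, with a stated time of 4 days (on this read-out higher numbers stand for weaker inhibition and lower numbers for stronger inhibition), compound 1 gives 2510 nM. Compound 2 `Oc1ccc(Nc2nc(-c3ccncc3)cs2)cc1` has a hydroxy in that place, and in this assay compound 2 gives 5370 nM. Among the two numbers recorded so far, compound 2 stands at the highest, with compound 1 nearest; the change from methyl to hydroxy, a 2.1-fold higher number from compound 1 to compound 2 (0.33 log units; beyond the scatter), was a modest rise, just beyond the usual scatter. Compound 3 `FC(F)(F)c1ccc(Nc2nc(-c3ccncc3)cs2)cc1` differs from compound 2 by trifluoromethyl in place of hydroxy on an aromatic carbon, the new group sitting para to a large group. Going by the values given here, the only measured step that bears on this change is the one that introduced the hydroxy, a 2.1-fold higher number from compound 1 to compound 2 (0.33 log units; beyond the scatter), and compound 3 removes that same hydroxy again, putting in its place a group that, like methyl, is not a hydroxy. The expected step in this assay is therefore a 1.9-fold lower number from compound 2 to compound 3 (0.28 log units; within the scatter), modest and opposite in direction, because the earlier rise a 2.1-fold higher number from compound 1 to compound 2 (0.33 log units; beyond the scatter) was itself modest. Compound 3 is estimated at 2800 nM, with a range from 1200 nM to 6500 nM.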

Compound 3, half-maximal inhibitory concentration: 40700 nM
The estimate for compound 3 lay 15-fold (1.16 log units) below the measured number, and the stated range ends below it.
By their numbers in this assay, from the lowest: compound 1; then compound 2; then compound 3.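

In this assay, this position proves far more sensitive than the first pair suggested: trifluoromethyl in place of hydroxy gives a 7.6-fold higher number from compound 2 to compound 3 (0.88 log units; beyond the scatter), and trifluoromethyl in place of methyl gives a 16-fold higher number from compound 1 to compound 3 (1.21 log units; beyond the scatter). Losing the hydroxy is therefore not enough to bring the number back towards that of compound 1, since neither compound 1 nor compound 3 carries a hydroxy, yet their numbers lie far apart. Methyl and hydroxy differ only modestly, by a 2.1-fold higher number from compound 1 to compound 2 (0.33 log units; beyond the scatter), so the larger shift seen here belongs to trifluoromethyl, and inhibition on these cells clearly depends on which group occupies this place on the ring.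

Nothing measured here on the groups themselves accounts for the jump, so its origin remains unknown. Three groups also cannot show whether others at this place, such as an amine, a chlorine atom, a carboxylic acid or a longer chain like ethyl, would stay close to compound 1 or climb towards compound 3.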